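Methoxy Replaces Trifluoromethyl at the Assay Limit

The source may report more compounds than this note shows. Statements on the series, on what has been measured and on what is new or still open speak of the compounds shown alone.

In an ADME assay on Vero cells (Chlorocebus sabaeus) for cytotoxicity, with a stated time of 72 h (a higher number here means a weaker inhibitor, a lower number a stronger inhibitor), compound 1 (`CCOC(=O)c1cc(/C=C/c2cccc(C(F)(F)F)c2)on1`) gives > 128000 nM as a limit, not a number. Compound 2 (`CCOC(=O)c1cc(/C=C/c2ccccc2SC)on1`) gives > 128000 nM as a limit as well. Compound 3 (`CCOC(=O)c1cc(/C=C/c2ccc(C)c3ccccc23)on1`) also gives > 128000 nM as a limit. Among the measured compounds shown here, compound 1 therefore has no exact value, and no measured step is available to guide the next change. Compound 4 (`CCOC(=O)c1cc(/C=C/c2cccc(OC)c2)on1`) carries methoxy in place of trifluoromethyl on an aromatic carbon. For compound 1 and its two companions the record shows only the limit of > 128000 nM in this assay, at which 3 of the 3 values shown sit, and so no shift beyond the scatter is expected. The estimated step, a number no higher from compound 1 to compound 4 (the limit leaves the size open), has no expected direction. Compound 4 is expected to read 128000 nM with an estimated range of 64000 nM to 256000 nM in this measurement.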

Compound 4, half-maximal inhibitory concentration: > 128000 nM
Compound 4 gave a limit, no number (the forecaster's own chance of this, stated with the estimate: 85%); the middle value sits exactly at the limit.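

No step can be read between compound 1 and compound 4, since both stand only at a limit in this assay: the limit of > 128000 nM in this assay, at which 4 of the 4 values shown sit.

How far any of these compounds lies beyond that limit stays open, as does whether methoxy and trifluoromethyl differ here.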